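Cyanophenyl for cyclohexyl: compound 3 to compound 4

The source may report more compounds than this note shows. Statements on the series, on what has been measured and on what is new or still open speak of the compounds shown alone.

Compound 3 `CC(C)(C)n1nnc2c1CCC(c1nc(C3CCCCC3)no1)C2` sits lowest of the three measured in a functional assay on U2OS cells with metabotropic glutamate receptor 5 (Homo sapiens) as the target, read by calcium flux (a lower number here means a smaller maximal response, a higher number a larger maximal response), where compound 3 gives 91%. Compound 2 `CC1(n2nnc3c2CCC(c2nc(-c4ccc(F)cc4)no2)C3)CCOCC1` gives 103% and compound 1 `Fc1ccc(-c2noc(C3CCc4c(nnn4-c4ccc(F)cc4)C3)n2)cc1` gives 106%; both gaps to compound 3 lie beyond the scatter, whereas a number 3 percentage points lower from compound 1 to compound 2 (within the scatter) stayed within it. Compound 4 `CC(C)(C)n1nnc2c1CCC(c1nc(-c3ccc(C#N)cc3)no1)C2` differs from compound 3 by 4-cyanophenyl in place of cyclohexyl on an aromatic carbon. Among the measured compounds shown here, no measured step touches this place: the one recorded step concerns the aromatic nitrogen, and compound 2 and compound 3 differ in two places at once, so only their values can be compared. Still, compound 1 and compound 2, each carrying 4-fluorophenyl on that aromatic carbon, sit above compound 3. A modest rise is therefore expected, a number 9 percentage points higher from compound 3 to compound 4 (within the scatter). Compound 4 is estimated at 100%, within 88% to 112%.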

Compound 4, largest response reached (reported as percent of maximum), in percent of the reference or control that the assay uses: 87%
Compound 4: the middle estimate sits 13 percentage points above what was measured, outside the stated range (below it).
By their numbers in this assay, from the lowest: compounds 4 and 3 (each within the scatter of the next); then compounds 2 and 1 (each within the scatter of the next).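

In this assay, among the compounds shown here, the one step at this aromatic carbon reads a number 4 percentage points lower from compound 3 to compound 4 (within the scatter), so this change does not separate 4-cyanophenyl from cyclohexyl. With the rest of compound 3 held fixed, a six-membered aromatic ring carrying a nitrile and a six-membered non-aromatic ring of carbon only are thus not told apart at this position. Nothing on hand bears on why this is so.

Still open, as far as these compounds go, is how 4-fluorophenyl would read at this carbon with the nitrogen substituent of compound 3 kept in place. Also open, from the compounds shown here alone, is how an amine or a carboxylic acid on the phenyl ring would read.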